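A few compounds are considered here, and "the series" means these few. Any claim that something is new, unique, unknown or untested is made for them only; others in the source may bear on it.

Three compounds share one core and differ only in the ring attached to the carbonyl carbon. In an assay on CHO cells with metabotropic glutamate receptor 5 (Homo sapiens) as the target (a higher number here means that more compound is needed for the effect, a lower number that less compound is needed), compound 1 `O=C(Nc1cc(-c2ccccc2)nn1-c1ccccc1)c1ccccc1F` gives 75 nM. Compound 2 `Cc1ccc(C(=O)Nc2cc(-c3ccccc3)nn2-c2ccccc2)cc1` gives 30 nM in this assay. Compound 3 `O=C(Nc1cc(-c2ccccc2)nn1-c1ccccc1)c1ccsc1` gives 1800 nM in this assay, the highest of the three numbers, so of this set it needs the most compound for the effect. The next compound, compound 4 `O=C(Nc1cc(-c2ccccc2)nn1-c1ccccc1)c1ccccc1O`, differs from compound 3 in one place: 2-hydroxyphenyl in place of thiophen-3-yl on a carbonyl carbon. Among the compounds with values here, two measured steps bear on this change, both running the other way: a 24-fold higher number from compound 1 to compound 3 (1.38 log units; beyond the scatter) and a 60-fold higher number from compound 2 to compound 3 (1.78 log units; beyond the scatter). In each, a six-membered ring of carbon only gave way to thiophen-3-yl and the number rose by a large amount. Going back to a six-membered ring of carbon only, now 2-hydroxyphenyl, is therefore expected to bring a large step downward in this assay. The step of a 2.5-fold lower number from compound 1 to compound 2 (0.40 log units; beyond the scatter), between two such six-membered rings, was only modest, so the exact group on the ring matters less than the ring type. Compound 4 is expected to give about 100 nM in this assay, within 30 nM to 400 nM. This is expected to amount to the step of an 18-fold lower number from compound 3 to compound 4 (1.26 log units; beyond the scatter).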

Compound 4, half-maximal effective concentration: > 10000 nM
Compound 4: no number, only a limit (the forecaster's own chance of this, stated with the estimate: 5%); middle value at least 100-fold (2.00 log units) from the limit.
By their numbers in this assay, from the lowest: compound 2; then compound 1; then compound 3. At a limit, above all of these: compound 4.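

Compound 4 has no number in this assay, only a limit of the assay: the limit of > 10000 nM in this assay, at which 1 of the 4 values shown sits. The six-membered ring of carbon only is therefore not enough on its own at this carbonyl carbon, since 2-hydroxyphenyl does not restore the effect but gives an at least 5.5-fold higher number from compound 3 to compound 4 (0.74 log units; beyond the scatter), and the exact group on the ring can matter as much as the ring type. Against 4-methylphenyl the change gives an at least 330-fold higher number from compound 2 to compound 4 (2.52 log units; beyond the scatter), and the single swap of fluoro for hydroxy gives an at least 130-fold higher number from compound 1 to compound 4 (2.12 log units; beyond the scatter), far more than the modest 2.5-fold lower number from compound 1 to compound 2 (0.40 log units; beyond the scatter) seen earlier.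

On these data alone, whether an amine or a methoxy group in place of the hydroxy would behave the same stays open. Also open, as far as these compounds go, is whether the hydroxy would have the same effect elsewhere on the ring, and how large the steps to compound 4 really are.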